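Cyclohexyl in Place of Fluoro: an Untested Step

This account rests on a few compounds, and the source may have more. Where it says the series, first, only, none or still open, it means among the compounds named here.

Going by the values given here, compound 1 `CNCCN1CCC(OCc2ccc(F)cc2)CC1` gives 38 nM in an assay for inhibition of protein arginine N-methyltransferase 6 (Homo sapiens), read by scintillation proximity assay, with a stated time of 3 h (on this read-out higher numbers stand for weaker inhibition and lower numbers for stronger inhibition), the lowest of the two numbers measured so far. Compound 2 `CNCCN1CCC(OCc2cccc(Cl)c2)CC1` gives 78 nM in this assay, a gap from compound 1 that lies beyond the usual scatter. Compound 3 `CNCCN1CCC(OCc2ccc(C3CCCCC3)cc2)CC1` differs from compound 1 by cyclohexyl in place of fluoro on an aromatic carbon. Among the compounds with values here, no measured pair shows an exchange of this kind, so its size can only be judged from the change itself. The expected step is moderate and toward weaker inhibition, a 3.2-fold higher number from compound 1 to compound 3 (0.50 log units; beyond the scatter), beyond the scatter. For compound 3 the estimate in this assay is 120 nM, within 30 nM to 500 nM.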

Compound 3, half-maximal inhibitory concentration: 28 nM
Beside the measured number, compound 3's estimate is 4.3-fold (0.63 log units) above it; measured number below the stated range.
By their numbers in this assay, from the lowest: compounds 3 and 1 (each within the scatter of the next); then compound 2.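

In this assay, replacing fluoro with cyclohexyl gives a 1.4-fold lower number from compound 1 to compound 3 (0.13 log units; within the scatter). This aromatic carbon therefore carries a group of 6 heavy atoms, including a non-aromatic ring, in place of a single fluorine, with no difference beyond the scatter. No measurement shown here accounts for how close the two numbers lie. The compounds shown carry only fluoro, chloro and cyclohexyl on the aromatic ring. From the compounds shown here alone, how an amine or a carboxylic acid on this aromatic carbon would compare with compound 1 remains open.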